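Diaryl ureas on a tolyl core: widening the chloro pattern

This account rests on a few compounds, and the source may have more. Where it says the series, first, only, none or still open, it means among the compounds named here.

Compound 1 `CC(=O)Nc1cc(NC(=O)Nc2ccccc2Cl)ccc1C` — > 30000 nM
Compound 2 `CC(=O)Nc1cc(NC(=O)Nc2ccc(Cl)c(Cl)c2)ccc1C` — 2100 nM
Compound 3 `Cc1ccc(NC(=O)Nc2ccccc2Cl)cc1NC(=O)c1ccccc1` — > 30000 nM

Three diaryl ureas have been measured in a functional assay on A375P cells (Homo sapiens) for antiproliferative activity; a lower number here means a stronger inhibitor, a higher number a weaker inhibitor. Compound 1 gives only a limit of the assay, > 30000 nM. Compound 2 gives 2100 nM. Compound 3 likewise reaches only a limit of the assay, > 30000 nM, so its place among the measured values cannot be read more closely than that.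

Among the measured compounds shown here, the one measured step, phenyl in place of methyl on the carbonyl carbon, a step that the two limits leave unreadable from compound 1 to compound 3; it is caught on both sides by the limit of > 30000 nM in this assay, at which 2 of the 3 values shown sit, and says nothing about size.

Compound 4 `Cc1ccc(NC(=O)Nc2ccc(Cl)c(Cl)c2)cc1NC(=O)c1ccccc1` differs from compound 3 by 3,4-dichlorophenyl in place of 2-chlorophenyl on an amide-type nitrogen. The pair compound 1 and compound 2 shows the same exchange on the shared core with the acetyl group: compound 2, with 3,4-dichlorophenyl, gives a numbered value where compound 1 gives only a limit. Compound 4 is therefore expected to leave the limit and move downward by about an at least 12-fold lower number from compound 3 to compound 4 (1.07 log units; beyond the scatter), in the direction of stronger inhibition. The estimate for compound 4 in this assay is 2500 nM, with a range from 600 nM to 12000 nM.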

Compound 4, half-maximal inhibitory concentration: 5800 nM
For compound 4 the middle estimate is 2.3-fold (0.37 log units) below the measured one; the range from low to high includes it.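

In this assay, the exchange of 2-chlorophenyl for 3,4-dichlorophenyl on the amide-type nitrogen also lifts the phenyl series off its limit, giving an at least 5.1-fold lower number from compound 3 to compound 4 (0.71 log units; beyond the scatter). The gain in inhibition seen with the acetyl group in compound 2 therefore holds when phenyl stands on the carbonyl carbon, and compound 4 carries a numbered value just as compound 2 does. With 3,4-dichlorophenyl in place, the exchange of methyl for phenyl on the carbonyl carbon can be read for the first time, as a 2.8-fold higher number from compound 2 to compound 4 (0.44 log units; beyond the scatter), which is a modest loss of inhibition in this assay, while the same exchange with 2-chlorophenyl cannot be read: the limit of > 30000 nM in this assay, at which 2 of the 4 values shown sit.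

The compounds shown leave open how much of the gain belongs to each of the two chlorine atoms of 3,4-dichlorophenyl, since both differ from the single chlorine of 2-chlorophenyl in one exchange. They also leave open whether a group such as an amine or a longer chain on the carbonyl carbon would keep inhibition in this assay closer to that of compound 2 or lose more of it.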